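Removing the methyl from the alkene of compound 3

A few compounds are considered here, and "the series" means these few. Any claim that something is new, unique, unknown or untested is made for them only; others in the source may bear on it.

Three thioether analogues of the shared core have been examined in a functional assay on a cell-free system (plasma) for inhibition of thromboxane A2 receptor (Homo sapiens); on this read-out higher numbers stand for weaker inhibition and lower numbers for stronger inhibition. Compound 1 `CCCCCCCSC1C2CCC(O2)C1C/C=C\CCCC(=O)O` carries a straight saturated chain on sulfur and gives 230000 nM; 35000 nM (2 entries) in this assay. Compound 2 `CCCCC(O)CSCC1C2CCC(O2)C1C/C=C\CCCC(=O)O`, whose chain bears a hydroxyl, gives 19000 nM; 10000 nM (2 entries). Compound 3 `CCC/C=C(\C)CSCC1C2CCC(O2)C1C/C=C\CCCC(=O)O`, with a branched unsaturated chain, gives 1100 nM, the lowest of the numbers shown; two further entries for compound 3 carry no single number. The step to compound 4 `CCC/C=C\CSCC1C2CCC(O2)C1C/C=C\CCCC(=O)O` is a group of 5 heavy atoms (5 carbon; no ring) in place of a group of 6 heavy atoms (6 carbon; no ring), on a saturated chain carbon bound to a sulfur, so that a pent-1-en-1-yl group replaces the branched chain on the saturated chain carbon bound to a sulfur. Among the measured compounds shown here, no measured pair here differs in the same way, so the size of this step is not fixed by the data. The expected change from compound 3 to compound 4 in this assay is small, a 1.8-fold higher number from compound 3 to compound 4 (0.26 log units; within the scatter), a slight weakening or none beyond the scatter. Compound 4 is therefore estimated at 2000 nM in this assay, within a range from 700 nM to 6000 nM.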

Compound 4, half-maximal inhibitory concentration: 5700 nM
Estimate against measurement, compound 4: 2.9-fold (0.45 log units) below; the measured number falls inside the stated range.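

In this assay, among the compounds shown here, the change gives the first step read between compounds that differ in one place: a 5.2-fold higher number from compound 3 to compound 4 (0.71 log units; beyond the scatter). The group that leaves and the pent-1-en-1-yl that enters each hold one double bond and no hydrogen-bond donors or acceptors, so this step follows the loss of the methyl alone, and the read-out at this position is sensitive to that single branch. The step is modest, and repeat entries in this assay can lie far apart, so its size is not firmly fixed: the several entries of compound 1 in this assay, 230000 nM; 35000 nM (2 entries)

The compounds shown leave open whether an ethyl group or a fluorine in place of that methyl would lower or raise the number. They also leave open whether a methyl at this place would give a step of like size on a chain bearing a hydroxyl.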